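The source may hold more compounds than are shown below. What is called first, only, known or untested is meant among the compounds shown, and "the series" means these compounds.

The measured compounds in an assay on isolated protein for binding affinity to Leucine-rich repeat serine/threonine-protein kinase 2 (Homo sapiens), read by TR-FRET and LanthaScreen, with a stated time of 2 h; a higher number here means a weaker inhibitor, a lower number a stronger inhibitor:
compound 1 `Cc1nn(C)cc1Nc1nc(N)c2c(C#N)c(N3CCC[C@H]3C)n(C)c2n1` gives 1 nM
compound 2 `Cn1c(N2CCCC2)c(C#N)c2c(N)ncnc21` gives 41 nM
compound 3 `C[C@H]1CCCN1c1c(C#N)c2c(N)ncnc2n1C` gives 136 nM

Compound 3 stands highest of the three in this assay. Its nearest neighbour is compound 2, the step being a 3.3-fold higher number from compound 2 to compound 3 (0.52 log units; beyond the scatter); compound 1 lies far lower still, as the two values show.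

Compound 4 `C[C@@H]1CCCN1c1c(C#N)c2c(N)ncnc2n1C` differs from compound 3 in this way: the two compounds have the same atoms and bonds and differ only in configuration as drawn: 1 of 1 stereo elements differ; a stereocentre at a saturated ring carbon is drawn S in compound 3 and R in compound 4. Within the data shown here, no measured step concerns a change of configuration alone; the only step, a 3.3-fold higher number from compound 2 to compound 3 (0.52 log units; beyond the scatter), concerns adding the methyl, not which way it points. Mirror-image pairs can differ little or greatly, so the expectation is uncertain. Compound 4 is expected to be somewhat weaker than compound 3, a step of a 2.2-fold higher number from compound 3 to compound 4 (0.34 log units; beyond the scatter) in this assay. The estimate for compound 4 is 300 nM, in the range 60 nM to 1500 nM.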

Compound 4, inhibition constant: 0.4 nM
Compound 4: middle estimate off by 750-fold (2.88 log units), on the high side, and the stated range ends above it.
By their numbers in this assay, from the lowest: compound 4; then compound 1; then compound 2; then compound 3.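

At the saturated ring carbon, configuration alone produces a 340-fold lower number from compound 3 to compound 4 (2.53 log units; beyond the scatter), and the ground for that is plain: the fact that compounds 3 and 4 differ only in the configuration as drawn. The same methyl in place of hydrogen can therefore go either way, with a 3.3-fold higher number from compound 2 to compound 3 (0.52 log units; beyond the scatter) for one configuration but a 100-fold lower number from compound 2 to compound 4 (2.01 log units; beyond the scatter) for the other. A low number also does not depend on the (1,3-dimethyl-1H-pyrazol-4-yl)amino on the aromatic carbon, given a 2.5-fold lower number from compound 1 to compound 4 (0.40 log units; beyond the scatter).

As far as these compounds go, how an ethyl group or a fluorine in place of this methyl would fare remains open. The compounds shown also cannot tell why the two configurations differ so widely.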